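Dichlorophenyl swap in a series resting at its limit

This account rests on a few compounds, and the source may have more. Where it says the series, first, only, none or still open, it means among the compounds named here.

Measured in a functional assay on A549 cells (Homo sapiens) for cytotoxicity, read by MTT assay, with a stated time of 72 h; on this read-out higher numbers stand for weaker inhibition and lower numbers for stronger inhibition:
compound 1 `COc1cccc(/C=C2\CCC/C(=C\c3ccc(Br)cc3)C2=O)c1OC`: > 20000 nM, a limit
compound 2 `COc1ccc(/C=C2\CCC/C(=C\c3cccc(OC)c3OC)C2=O)cc1`: > 20000 nM, a limit
compound 3 `COc1cccc(/C=C2\CCC/C(=C\c3ccc(O)cc3)C2=O)c1OC`: > 20000 nM, a limit

Compound 3 gives > 20000 nM, which is a limit and not a number. Within the data shown here, the whole series so far shows one picture: the limit of > 20000 nM in this assay, at which 3 of the 3 values shown sit. Compound 4 `COc1cccc(/C=C2\CCC/C(=C\c3cc(Cl)cc(Cl)c3)C2=O)c1OC` differs from compound 3 by 3,5-dichlorophenyl in place of 4-hydroxyphenyl on a double-bonded chain carbon bound to a double-bonded ring carbon. Three measured steps change the group at this place: a step that the two limits leave unreadable from compound 1 to compound 3, a step that the two limits leave unreadable from compound 2 to compound 3 and a step that the two limits leave unreadable from compound 1 to compound 2. None of them has a readable size, and none gives a direction in this assay. The expected step is an at least 1.2-fold lower number from compound 3 to compound 4 (0.09 log units; that floor lies within the scatter), small if present, with a slight lean towards stronger inhibition. For compound 4 the estimate is 16000 nM, with an expected range from 6000 nM to 30000 nM.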

Compound 4, half-maximal inhibitory concentration: 12500 nM
Estimate against measurement, compound 4: 1.3-fold (0.11 log units) above; the range from low to high includes it.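

Of the compounds shown, compound 4 with its 3,5-dichlorophenyl is the only one at this place to give a number rather than a limit in this assay: the limit of > 20000 nM in this assay, at which 3 of the 4 values shown sit. Replacing the other groups gives an at least 1.6-fold lower number from compound 3 to compound 4 (0.20 log units; that floor lies within the scatter), an at least 1.6-fold lower number from compound 2 to compound 4 (0.20 log units; that floor lies within the scatter) and an at least 1.6-fold lower number from compound 1 to compound 4 (0.20 log units; that floor lies within the scatter). Each step is only a floor within the scatter, so a real gain is not established, and the steps among compound 1, compound 2 and compound 3 cannot be read.

Open, on these data alone, is whether both chlorine atoms matter, and whether a monochlorophenyl, aminophenyl or carboxyphenyl group at this place would also give a number.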